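The source may report more compounds than this note shows. Statements on the series, on what has been measured and on what is new or still open speak of the compounds shown alone.

For the measured compounds named here, compound 1, with the structure `Cc1[nH]n(-c2nc3cc(C(C)(C)C)ccc3[nH]2)c(=O)c1Cc1ccccc1`, is one of two compounds measured so far in an assay on isolated protein for inhibition of alpha-ketoglutarate-dependent dioxygenase alkB homolog 3 (Homo sapiens), read by polymerase chain reaction, with a stated time of 1 h; on this read-out lower numbers stand for stronger inhibition and higher numbers for weaker inhibition. In this assay compound 1 gives 640 nM, the lower of the two numbers. Its nearest neighbour is compound 2, with the structure `Cc1ccc2[nH]c(-n3[nH]c(C)c(Cc4ccc(Cl)c(Cl)c4)c3=O)nc2c1`, which in this assay gives 720 nM; the gap between these two values lies within the usual scatter, so neither can be called the stronger inhibitor.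

Compound 3, with the structure `Cc1[nH]n(-c2nc3cc(-c4ccc(Cl)cc4)ccc3[nH]2)c(=O)c1Cc1ccccc1`, has not yet been measured. It is derived from compound 1 by one change: 4-chlorophenyl in place of tert-butyl on an aromatic carbon. Going by the values given here, no pair of measured compounds shows what this kind of exchange does, so the data give no step to lean on.

Without such a guide, the expected step from compound 1 to compound 3 in this assay is a 1.4-fold lower number from compound 1 to compound 3 (0.15 log units; within the scatter), a shift that would not clearly exceed the scatter. The estimate for compound 3 in this assay is therefore 450 nM, with a plausible range from 120 nM to 1700 nM.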

Compound 3, half-maximal inhibitory concentration: 1500 nM
Compound 3: middle estimate off by 3.3-fold (0.52 log units), on the low side; the range from low to high includes it.
By their numbers in this assay, from the lowest: compounds 1 and 2 (each within the scatter of the next); then compound 3.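

For the compounds shown here, this is the first step that can be read at this position, an aromatic carbon of a six-membered aromatic ring of carbon only, part of a fused system of two rings. In this assay, 4-chlorophenyl in place of tert-butyl gives a 2.3-fold higher number from compound 1 to compound 3 (0.37 log units; beyond the scatter), a modest weakening of inhibition, so what sits on this carbon does affect the result, though compound 3 still gives a measurable 1500 nM even with a ring added at this position. Nothing available explains why the number rises.

Compound 2 differs from compound 1 and compound 3 in more than one place, so it cannot show how this exchange behaves on another background, and this single step cannot separate the effect of the added ring from that of its chlorine. Going by these compounds, it remains open how a plain phenyl, a primary amine or a carboxylic acid on this same carbon would compare with tert-butyl, and so whether any group here can give a lower number than compound 1 does.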